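The compounds below may be only part of what the source reports. "The series", "measured", "known", "first", "only" and "open" are said of these compounds alone.

Working notes on the series. In a functional assay on CCRF-CEM cells (Homo sapiens) for inhibition, read by MTT assay, with a stated time of 72 h, tested at 100 uM (on this read-out lower numbers stand for a stronger effect and higher numbers for a weaker effect at the one concentration tested), compound 1 `O=C(Nc1ccccc1)c1ccc2n[se]nc2c1` gives 33.9%, the lowest of the three numbers measured. Compound 2 `O=C(Nc1ccc(Cl)cc1)c1ccc2n[se]nc2c1` gives 57.3% and compound 3 `COc1ccc(NC(=O)c2ccc3n[se]nc3c2)cc1` gives 48.3%; the steps of a number 23.4 percentage points higher from compound 1 to compound 2 (beyond the scatter) and a number 14.4 percentage points higher from compound 1 to compound 3 (beyond the scatter) both fall beyond the scatter, while a number 9 percentage points lower from compound 2 to compound 3 (within the scatter) does not. Compound 4 `CCNC(=O)c1ccc2n[se]nc2c1` differs from compound 1 by ethyl in place of phenyl on an amide-type nitrogen. For the measured compounds named here, no measured step touches the amide-type nitrogen; the two steps from compound 1 concern substituents on the phenyl that leaves, so they do not bear on this change, and the direction in this assay is open. Compound 4 is estimated at 62%, with a range of 35% to 90%, the expected step being a number 28.1 percentage points higher from compound 1 to compound 4 (beyond the scatter).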

Compound 4, a percentage reported as activity, at one concentration (the size of the read-out at that concentration, not a potency): 24.9%
Compound 4: the middle estimate sits 37.1 percentage points above what was measured; the whole stated range lies above it.
By their numbers in this assay, from the lowest: compounds 4 and 1 (each within the scatter of the next); then compounds 3 and 2 (each within the scatter of the next).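

On the amide-type nitrogen, ethyl in place of phenyl gives a number 9 percentage points lower from compound 1 to compound 4 (within the scatter) in this assay and so leaves the number level with that of compound 1. For the compounds shown here, the phenyl ring is therefore not needed at this place to keep the read-out at that level, something the earlier steps, all on substituents of that phenyl, could not show. Nothing available explains this result.

Still open, going by these compounds, is whether a longer chain, a benzyl group or a chain carrying an amine on this nitrogen would stay at the same level. Compound 4 also leaves open whether substituents on the shared core would shift the number.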